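Swapping Phenyl for Cyclopentyloxy in a Guanidine Series

The source may report more compounds than this note shows. Statements on the series, on what has been measured and on what is new or still open speak of the compounds shown alone.

Compound 1, `Cc1c(C(=O)N=C(N)N)cc(S(C)(=O)=O)c(Cl)c1C`: in a functional assay for inhibition of sodium/hydrogen exchanger (Oryctolagus cuniculus) (a lower number here means a stronger inhibitor, a higher number a weaker inhibitor), compound 1 gives 58 nM.
Compound 2, `Cc1cc(-c2ccccc2)c(S(C)(=O)=O)cc1C(=O)N=C(N)N`: in this assay compound 2 gives 19 nM.
Compound 3, `CCc1cc(OC)c(S(C)(=O)=O)cc1C(=O)N=C(N)N`: in this assay compound 3 gives 30 nM.

Compound 2 has the lowest number of the three in this assay. Its gap to compound 3 lies within the usual scatter of repeated measurements, so these two cannot be ranked against each other; its gap to compound 1 lies beyond the scatter, so compound 2 is the stronger inhibitor of that pair.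

Compound 4, `Cc1cc(OC2CCCC2)c(S(C)(=O)=O)cc1C(=O)N=C(N)N`, differs from compound 2 in one place: cyclopentyloxy in place of phenyl on an aromatic carbon. Among the compounds with values here, no measured pair shows exactly this change. Compound 3, which carries a methoxy group and an ethyl group where compound 2 carries phenyl and methyl, gives a number within the scatter of compound 2, so an oxygen-linked group in this series has not so far moved the number much. The step from compound 2 to compound 4 is therefore expected to be small, perhaps a slight weakening, and likely within the scatter: a 1.5-fold higher number from compound 2 to compound 4 (0.17 log units; within the scatter). In this assay compound 4 is estimated at 28 nM, with a plausible range from 9 nM to 90 nM.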

Compound 4, half-maximal inhibitory concentration: 27 nM
Estimate against measurement, compound 4: 1.0-fold (0.02 log units) above, and the stated range covers the measured number.
By their numbers in this assay, from the lowest: compounds 2, 4, 3 and 1 (each within the scatter of the next, the first and the last beyond it).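

Within the data shown here, this is the first direct pair at the place ortho to the methylsulfonyl group: in this assay, replacing phenyl with cyclopentyloxy gives a 1.4-fold higher number from compound 2 to compound 4 (0.15 log units; within the scatter), so compound 2 and compound 4 cannot be ranked against each other. For this pair, then, a six-membered aromatic ring of carbon and an oxygen-linked five-membered non-aromatic ring, each of 6 heavy atoms, give numbers that cannot be told apart, even though only cyclopentyloxy carries a hydrogen-bond acceptor. Nothing measured here offers an explanation for this result.

The compounds shown leave open whether a quite different group at this place, such as an amine or a carboxylic acid, would give a similar number. They also leave open whether a longer chain joined through oxygen would do so.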